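Changing the Aryl Group on the Amide Nitrogen

The source may hold more compounds than are shown below. What is called first, only, known or untested is meant among the compounds shown, and "the series" means these compounds.

Three compounds built on one shared core differ only in the aryl group carried by an amide-type nitrogen. Compound 1 `Cc1ccc(NC(=O)COc2ccc3cc(/C=C4/SC(=O)NC4=O)ccc3c2)cc1` was tested in a functional assay on Ramos cells (Homo sapiens) for cytotoxicity, with a stated time of 20 h (on this read-out lower numbers stand for higher toxicity in this test and higher numbers for lower toxicity in this test), where compound 1 gives 7000 nM. Compound 2 `O=C(COc1ccc2cc(/C=C3/SC(=O)NC3=O)ccc2c1)Nc1cccc(Cl)c1` gives 9100 nM in this assay, and compound 3 `O=C(COc1ccc2cc(/C=C3/SC(=O)NC3=O)ccc2c1)Nc1c(F)cc(F)cc1Br` gives 9600 nM. Compound 3 shows the highest of the three numbers, but its steps to the others are small: a 1.4-fold higher number from compound 1 to compound 3 (0.14 log units; within the scatter) and a 1.1-fold higher number from compound 2 to compound 3 (0.02 log units; within the scatter), both within the scatter, as is a 1.3-fold higher number from compound 1 to compound 2 (0.11 log units; within the scatter). So far, exchanging one aryl group for another on this nitrogen has not moved the read-out beyond what repeated measurement would show.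

Compound 4 `COc1cccc(NC(=O)COc2ccc3cc(/C=C4/SC(=O)NC4=O)ccc3c2)c1` has not yet been measured. It differs from compound 3 in one place: 3-methoxyphenyl in place of 2-bromo-4,6-difluorophenyl on an amide-type nitrogen. All three measured steps bear on this change, since each also exchanges one aryl group for another on an amide-type nitrogen, and none went beyond the scatter. The expected step in this assay is therefore a 1.1-fold lower number from compound 3 to compound 4 (0.05 log units; within the scatter), a change within the scatter. Compound 4 is estimated to give about 8500 nM in this assay, with a likely range from 4000 nM to 18000 nM.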

Compound 4, half-maximal cytotoxic concentration: 9300 nM
For compound 4 the middle estimate is 1.1-fold (0.04 log units) below the measured one; the range from low to high includes it.
By their numbers in this assay, from the lowest: compounds 1, 2, 4 and 3 (each within the scatter of the next).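

In this assay, replacing 2-bromo-4,6-difluorophenyl with 3-methoxyphenyl gives a 1.0-fold lower number from compound 3 to compound 4 (0.01 log units; within the scatter), so this position has now taken an aryl group with 1 hydrogen-bond acceptor, where the group it replaces has 0, without the number leaving the scatter. The narrowest change so far, methoxy in place of chloro on an aromatic carbon, alters one substituent while the rest of the aryl group stays the same, and it gives a 1.0-fold higher number from compound 2 to compound 4 (0.01 log units; within the scatter). The comparison with the 4-methylphenyl compound gives a 1.3-fold higher number from compound 1 to compound 4 (0.12 log units; within the scatter), so the oxygen-bearing group joins the methyl-bearing and halogen-bearing groups, and all four compounds remain within the scatter of one another.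

No measurement is available that explains why these aryl groups give such similar numbers. The compounds shown leave open whether an aryl ring carrying an amine or a carboxylic acid, or a longer chain in place of the aryl ring on the amide-type nitrogen, would move the number beyond the scatter.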